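A few compounds are considered here, and "the series" means these few. Any claim that something is new, unique, unknown or untested is made for them only; others in the source may bear on it.

The study brings together four compounds built on one shared core. Compound 1, `O=S(=O)(CC1=NCCS1)C1C(c2ccccc2)=NOC1c1ccccc1`, and compound 3, `O=S(=O)(CC1=NCCO1)C1=NNCC1c1ccccc1`, are both reported as not active in a functional assay, tested at 50 ug/mL; a lower number here means a weaker effect, a higher number a stronger effect of the compound at the concentration tested: for compound 1 the entry reads "not active" (no number reported), and for compound 3 it reads "not active" (no number reported). Going by the values given here, compound 2, `Cc1ccc(C2CNN=C2S(=O)(=O)CC2=NCCS2)cc1`, is the only compound with a number, giving 39.8% in this assay. Among the compounds with values here, compound 3 therefore stands without a single number of its own, and it shares that position with one further entry, compound 1; no step between any two measured compounds that differ in one place is available here, so the pairs can only be compared on what their entries show.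

The piece follows compound 3 to compound 4, `Cc1ccc(C2CNN=C2S(=O)(=O)CC2=NCCO2)cc1`, a compound not yet tested in this assay. The change is methyl in place of hydrogen on an aromatic carbon. Within the data shown here, compound 2 carries the same methyl on the same ring and gives 39.8%, but it differs from compound 4 in another place too, so it offers no direct step. The expectation for compound 4 is nonetheless an upward move beyond the scatter, though a report of no activity remains possible. Compound 4 is estimated at 20% in this assay, within a range from 0% to 45%.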

Compound 4, a percentage reported as activity, at one concentration (the size of the read-out at that concentration, not a potency): 41.3%
The estimate for compound 4 lay 21.3 percentage points below the measured number; measured number inside the range.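

In this assay compound 3 is entered as "not active" (no number reported) and, with 4-methylphenyl where compound 3 has phenyl, compound 4 gives 41.3%; the size of this step cannot be read, but on the oxygen-containing five-membered ring the change goes with a move from an entry without a number to one with a number. The comparison on the other side exchanges the sulfur of the five-membered non-aromatic ring for oxygen, on the saturated chain carbon bound to the sulfonyl sulfur, and it gives a number 1.5 percentage points higher from compound 2 to compound 4 (within the scatter), so with the 4-methylphenyl group in place the two rings are not told apart in this assay. No measurement at hand bears on why the methyl group goes with this result.

The compounds shown leave open whether the methyl group itself matters, or whether a methoxy group, a chlorine atom or a longer chain such as ethyl on the same aromatic carbon would also give a number. They also leave open how these entries would look at other concentrations, since a single concentration gives the size of a read-out and not a potency.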